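The compounds below may be only part of what the source reports. "The series", "measured", "known", "first", "only" and "open" are said of these compounds alone.

Series notes. Compound 3 `O=C(O)CC[C@H](NC(=O)CN(c1nc(Cl)nc2[nH]cnc12)C1CC1)C(=O)O` gives 30.1% in a functional assay on the whole organism (Tail, strain ICR) with Mus musculus as the target, in the tail flick test, with a stated time of 120 min, at a dose of 25 umol/kg by the oral route; on this read-out lower numbers stand for a weaker effect and higher numbers for a stronger effect at the one dose given; of the three numbers in hand this is the highest, but compound 1 lies nearest and compound 2 furthest from it, both within the scatter, so no ranking is claimed. Compound 1 `NC(=O)CC[C@H](NC(=O)CN(c1ncnc2c1ncn2C1CCCCO1)C1CC1)C(=O)OCc1ccccc1` gives 22.3%, and compound 2 `O=C(CN(c1ncnc2c1ncn2C1CCCCO1)C1CC1)N[C@@H](CCC(=O)OCc1ccccc1)C(=O)OCc1ccccc1` gives 20.7%. For the measured compounds named here, the one measured step, a number 1.6 percentage points lower from compound 1 to compound 2 (within the scatter), concerns benzyloxy in place of amino on a carbonyl carbon and does not bear on the change now in question. Compound 4 `CSCC[C@H](NC(=O)CN(c1nc(Cl)nc2[nH]cnc12)C1CC1)C(=O)O` differs from compound 3 by methylsulfanyl in place of carboxy on a saturated chain carbon, three bonds along the chain from an amide-type nitrogen and a carbonyl carbon. Going by the values given here, no measured step covers methylsulfanyl in place of carboxy, so no shift beyond the scatter is expected; the estimated step is a number 2.1 percentage points lower from compound 3 to compound 4 (within the scatter). Compound 4 is expected to give 28%, with a range from 14% to 42%.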

Compound 4, a percentage reported as activity, at one dose (the size of the read-out at that dose, not a potency): 5.67%
Compound 4: middle estimate off by 22.3 percentage points, on the high side; measured number below the stated range.
By their numbers in this assay, from the lowest: compound 4; then compounds 2, 1 and 3 (each within the scatter of the next).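

The chain position is not indifferent in this assay, since methylsulfanyl in place of carboxy gives a number 24.4 percentage points lower from compound 3 to compound 4 (beyond the scatter). For the compounds shown here, this is the first step beyond the scatter; the earlier step, a number 1.6 percentage points lower from compound 1 to compound 2 (within the scatter), lies within it and concerns a different change. Nothing at hand accounts for the shift.

As far as these compounds go, it remains open whether the drop follows the loss of carboxy or the arrival of methylsulfanyl, which a carboxamide, a hydroxy group or a plain alkyl chain at this position could separate. From the compounds shown here alone, whether the step carries over to the core of compound 1 is also open.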